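Catechol to dinitro on the diaryl ether of compound 1

The compounds below may be only part of what the source reports. "The series", "measured", "known", "first", "only" and "open" are said of these compounds alone.

Going by the values given here, compound 1 `O=C(NCCNS(=O)(=O)c1ccc(-c2ccccc2Oc2ccc(O)c(O)c2)s1)Nc1cc(Cl)cc(Cl)c1` is the only member of this set with a numerical value in a functional assay on RS4-11 cells (Homo sapiens) for inhibition, read by CCK-8 assay, with a stated time of 48 h (on this read-out lower numbers stand for stronger inhibition and higher numbers for weaker inhibition), where compound 1 gives 4500 nM. Compound 2 `COc1cccc(NC(=S)NCCNS(=O)(=O)c2ccc(-c3ccccc3Oc3ccc([N+](=O)[O-])cc3)s2)c1` reaches only the assay limit, > 50000 nM. Compound 3 `O=S(=O)(NCCNC(=S)Nc1cccc(Cl)c1)c1ccc(-c2ccccc2OCc2ccccc2)s1` likewise returns only the limit, > 50000 nM. Thus the limit of > 50000 nM in this assay, at which 2 of the 3 values shown sit, describes two of the three results, and compound 1 stands alone as the one measurable point, so no measured step between neighbours is available.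

Compound 4 `O=C(NCCNS(=O)(=O)c1ccc(-c2ccccc2Oc2ccc([N+](=O)[O-])c([N+](=O)[O-])c2)s1)Nc1cc(Cl)cc(Cl)c1` keeps the core of compound 1 with one change: 3,4-dinitrophenyl in place of 3,4-dihydroxyphenyl on an oxygen on an aromatic ring. Among the compounds with values here, the catechol is the only motif that coincides with a numerical reading, and its removal leaves the series with no measured precedent on this scaffold.

In this assay compound 4 is expected to fall at 20000 nM, within 5000 nM to 60000 nM. The expected step of a 4.4-fold higher number from compound 1 to compound 4 (0.65 log units; beyond the scatter) is a loss beyond the scatter, with a real chance that only a limit is returned.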

Compound 4, half-maximal inhibitory concentration: 2100 nM
Compound 4: middle estimate off by 9.5-fold (0.98 log units), on the high side; measured number below the stated range.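

In this assay, 3,4-dinitrophenyl in place of 3,4-dihydroxyphenyl on an oxygen on an aromatic ring gives a 2.1-fold lower number from compound 1 to compound 4 (0.33 log units; beyond the scatter), a modest gain. The 3,4-dihydroxyphenyl group is therefore not needed for a numerical reading on the core of compound 1, and this place tolerates a group with 0 hydrogen-bond donors and a larger heavy-atom count. Compound 2 and compound 3 differ from compound 4 in more than one place and return only limits, so no steps to them can be read: the limit of > 50000 nM in this assay, at which 2 of the 4 values shown sit.

Going by these compounds alone, the single step does not separate the loss of the hydroxyl groups from the entry of the nitro groups. An unsubstituted phenyl, a 4-nitrophenyl or a 3,4-diaminophenyl on the same oxygen would show which of the two carries the change.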